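A Fluoro Group in Place of Nitro on an Aryl Urea

A few compounds are considered here, and "the series" means these few. Any claim that something is new, unique, unknown or untested is made for them only; others in the source may bear on it.

The measured compounds are:
compound 1, `N#CC1CN1C(=O)NCc1ccccc1`, which in a functional assay on OVCAR-3 cells (Homo sapiens) for inhibition (a lower number here means a stronger inhibitor, a higher number a weaker inhibitor), gives 5000 nM
compound 2, `N#CC1CN1C(=O)Nc1ccc([N+](=O)[O-])cc1`, which gives 6500 nM
compound 3, `N#CC1CN1C(=O)NC1CCCCC1`, which gives 31000 nM

Among these three numbers compound 2 stands second highest. Its value and that of compound 1 sit within the usual scatter of each other, so no order can be read between them; compound 3 has the clearly higher number of the set, and that gap lies beyond the scatter.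

Compound 4, `N#CC1CN1C(=O)Nc1ccc(F)cc1`, has not yet been measured. It differs from compound 2 in one place: fluoro in place of nitro on an aromatic carbon. Within the data shown here, no measured pair here shows such a change, so the step of a 1.2-fold higher number from compound 2 to compound 4 (0.09 log units; within the scatter) is expected to be small, most likely none beyond the scatter in either direction. Compound 4 is therefore estimated at 8000 nM, within a range from 2500 nM to 25000 nM.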

Compound 4, half-maximal inhibitory concentration: 5900 nM
Estimate against measurement, compound 4: 1.4-fold (0.13 log units) above; the measured number falls inside the stated range.
By their numbers in this assay, from the lowest: compounds 1, 4 and 2 (each within the scatter of the next); then compound 3.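

In this assay, among these compounds, fluoro in place of nitro on the aromatic carbon gives a 1.1-fold lower number from compound 2 to compound 4 (0.04 log units; within the scatter), the first comparison in this set between compounds that differ in one place. At this position, nitro, with 3 heavy atoms and 2 hydrogen-bond acceptors, and fluoro, with 1 heavy atom and no hydrogen-bond acceptors, give numbers that cannot be told apart. No measurement available here accounts for this agreement.

The compounds shown leave open whether an amine or a carboxylic acid on this same aromatic carbon would give a number beyond the scatter from these two. They also leave open how the ring would read with only a hydrogen there.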